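Aryl swap at the weak end of the series

The source may report more compounds than this note shows. Statements on the series, on what has been measured and on what is new or still open speak of the compounds shown alone.

In a functional assay on K562 cells (Homo sapiens) for antiproliferative activity, with a stated time of 72 h (on this read-out lower numbers stand for stronger inhibition and higher numbers for weaker inhibition), compound 1 (`CCCC#Cc1cc([C@@H]2O[C@H](CO)[C@@H](O)[C@H]2O)n2ncnc(N)c12`) gives 1100 nM. Compound 2 (`Nc1ncnn2c([C@@H]3O[C@H](CO)[C@@H](O)[C@H]3O)cc(C#Cc3ccccc3)c12`) reads > 100000 nM, which is a limit of the assay and not a number. Compound 3 (`COc1ccc(-c2cc([C@@H]3O[C@H](CO)[C@@H](O)[C@H]3O)n3ncnc(N)c23)cc1`) gives 76400 nM, the higher of the two actual numbers.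

Compound 4 (`Nc1ncnn2c([C@@H]3O[C@H](CO)[C@@H](O)[C@H]3O)cc(-c3ccccc3Cl)c12`) has 2-chlorophenyl in place of 4-methoxyphenyl on an aromatic carbon.

Going by the values given here, three measured steps bear on this change. Among the compounds with values here, both aryl-bearing compounds lie far from compound 1, with a 69-fold higher number from compound 1 to compound 3 (1.84 log units; beyond the scatter) and an at least 90-fold higher number from compound 1 to compound 2 (1.95 log units; beyond the scatter), both large and with no measured compound going against them. Between those two, an at least 1.3-fold lower number from compound 2 to compound 3 (0.11 log units; that floor lies within the scatter) has a floor within the scatter. Compound 4 keeps a phenyl ring on the same aromatic carbon as compound 3, so no step beyond the scatter is expected in this assay, and a further limit reading is possible. The expected change is a 1.1-fold lower number from compound 3 to compound 4 (0.04 log units; within the scatter). Compound 4 is estimated at 70000 nM, with an expected range of 20000 nM to 100000 nM.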

Compound 4, half-maximal inhibitory concentration: > 100000 nM
Compound 4 was reported as a limit (the forecaster's own chance of this, stated with the estimate: 40%); at least 1.4-fold (0.15 log units) between middle value and limit.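

In this assay compound 4 reads > 100000 nM, a limit of the assay, so a second aryl group attached directly to this aromatic carbon, here 2-chlorophenyl, also stays far from compound 1. With an at least 1.3-fold higher number from compound 3 to compound 4 (0.11 log units; that floor lies within the scatter), 2-chlorophenyl and 4-methoxyphenyl cannot be separated, while an at least 90-fold higher number from compound 1 to compound 4 (1.95 log units; beyond the scatter) adds a third large step away from the pent-1-yn-1-yl group; the step from compound 2 to compound 4 cannot be read. Limit readings now make up much of the series: the limit of > 100000 nM in this assay, at which 2 of the 4 values shown sit.

Going by these compounds, how far compound 2 and compound 4 lie past the limit stays open, so no order among the aryl-bearing compounds can be given. Also open, on these data alone, is whether a longer alkyl chain on the triple bond, or a phenyl ring carrying an amine, would come back toward compound 1.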